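Piperazine bis-dithiocarbamate series: cytotoxicity notes on compound 4

The source may hold more compounds than are shown below. What is called first, only, known or untested is meant among the compounds shown, and "the series" means these compounds.

Compound 1 `CN1CCN(C(=S)SC(=S)N(C)C)CC1` gives 1220000 nM in an ADME assay on HeLa cells (Homo sapiens) for cytotoxicity, read by MTT assay, with a stated time of 24 h; a lower number here means a stronger inhibitor, a higher number a weaker inhibitor. Compound 2 `CCOC(=O)N1CCN(C(=S)SC(=S)N(C)C)CC1` gives 530000 nM in this assay. Compound 3 `CN(C)C(=S)SC(=S)N1CCN(c2ncccn2)CC1` sits at a limit of this assay, > 5000000 nM, so only a boundary is known for it; this is the limit of > 5000000 nM in this assay, at which 1 of the 3 values shown sits, at which one of the three values rests. The step of a 2.3-fold lower number from compound 1 to compound 2 (0.36 log units; beyond the scatter) is modest, whereas an at least 4.0-fold higher number from compound 1 to compound 3 (0.61 log units; beyond the scatter) and an at least 9.4-fold higher number from compound 2 to compound 3 (0.97 log units; beyond the scatter) run the other way and are at least modest.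

Compound 4 `CCCCSC(=S)N1CCN(C(=S)SC(=S)N(C)C)CC1` differs from compound 3 by a group of 7 heavy atoms (5 carbon, 2 sulfur; no ring) in place of a group of 6 heavy atoms (4 carbon, 2 nitrogen; one six-membered aromatic ring with 2 hetero atoms), on an amine nitrogen in a ring. For the measured compounds named here, no measured step covers this exact exchange. The closest guide is the reverse of the step from compound 2 to compound 3, in which an acyclic group on the same ring nitrogen went with a lower number than pyrimidin-2-yl; compound 1 points the same way. Going by these compounds, a lower number than the limit of compound 3 is therefore expected for compound 4, though the true value of compound 3 is unknown, so the size is uncertain. On this basis the expected step is an at least 5.5-fold lower number from compound 3 to compound 4 (0.74 log units; beyond the scatter). For compound 4 the estimate in this assay is 900000 nM, with a range from 250000 nM to 4000000 nM.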

Compound 4, half-maximal inhibitory concentration: > 5000000 nM
Compound 4 was reported as a limit; the forecaster's own chance of this, stated with the estimate: 25%; middle value at least 5.5-fold (0.74 log units) away from the limit.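

In this assay, replacing the ethoxycarbonyl or the methyl on the amine nitrogen in the ring with the group of 7 heavy atoms (5 carbon, 2 sulfur; no ring) gives an at least 9.4-fold higher number from compound 2 to compound 4 (0.97 log units; beyond the scatter) and an at least 4.0-fold higher number from compound 1 to compound 4 (0.61 log units; beyond the scatter), so an acyclic group here does not by itself go with a lower number: compound 1 and compound 2 fit that reading, and compound 4 goes against it. Compound 3 and compound 4 both stand at a limit, so the step between them cannot be read, and a pyrimidin-2-yl group is not needed to reach that limit. Results at this position now gather at one boundary: the limit of > 5000000 nM in this assay, at which 2 of the 4 values shown sit.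

Going by these compounds, how far compound 3 and compound 4 lie beyond the limit remains unknown, so no order between them can be given. Also open, on these data alone, is where a carboxylic acid, a primary amine or a shorter alkyl chain on this nitrogen would fall.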